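This account rests on a few compounds, and the source may have more. Where it says the series, first, only, none or still open, it means among the compounds named here.

Compound 1 `COc1ccc(-c2cc(NO)c(C(=O)Nc3ccccc3)c(=O)o2)cc1`: in an ADME assay on Huh-7 cells (Homo sapiens) for cytotoxicity, read by a luciferase reporter and WST assay, with a stated time of 3 days (on this read-out higher numbers stand for lower toxicity in this test and lower numbers for higher toxicity in this test), compound 1 gives 16200 nM.
Compound 2 `O=C(Nc1ccc(Br)cc1)c1c(NO)cc(-c2ccccc2)oc1=O`: in this assay compound 2 gives > 20000 nM, which is a limit of the assay and not a number.

Compound 2 therefore stands only at the limit, as the limit of > 20000 nM in this assay, at which 1 of the 2 values shown sits, shows; no number is known for it. Compound 3 `COC(=O)c1ccc(NC(=O)c2c(NO)cc(-c3ccccc3)oc2=O)cc1` differs from compound 2 by methoxycarbonyl in place of bromo on an aromatic carbon. Among the compounds with values here, no measured step of this kind exists. The step of a number no higher from compound 2 to compound 3 (the limit leaves the size open) is expected to be none beyond the scatter, with a further limit likely. Compound 3 is estimated at 20000 nM, in the range 8000 nM to 50000 nM.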

Compound 3, half-maximal cytotoxic concentration: > 20000 nM
Compound 3: a limit, no number (the forecaster's own chance of this, stated with the estimate: 55%); the middle value sits exactly at the limit.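

Within the data shown here, compound 3, like compound 2, gives only a limit of the assay in this assay, so no step between the two can be read. The compounds shown leave open whether methoxycarbonyl in place of bromo on an aromatic carbon changes the read-out at all.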